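The source may hold more compounds than are shown below. What is called first, only, known or untested is meant among the compounds shown, and "the series" means these compounds.

Measured so far in a functional assay on L1210 cells (Mus musculus) for cytotoxicity; a higher number here means a weaker inhibitor, a lower number a stronger inhibitor:
- compound 1 `Cc1c2cc[n+](C)cc2c(C)c2c3c([nH]c12)C=CC(=O)[C@@]31O[C@@H]2[C@H](O1)[C@@H](COP(=O)(O)O)O[C@H]2n1cnc2c(N)ncnc21` gives > 0.8 uM, a limit of the assay
- compound 2 `Cc1c2cc[n+](C)cc2c(C)c2c3c([nH]c12)C=CC(=O)[C@@]31O[C@@H]2[C@H](O1)[C@@H](COP(=O)(O)O)O[C@H]2n1cnc2c(O)nc(N)nc21` gives > 1 uM, a limit of the assay
- compound 3 `Cc1c2cc[n+](C)cc2c(C)c2c3c([nH]c12)C=CC(=O)[C@@]31O[C@@H]2[C@H](O1)[C@@H](CO)O[C@H]2n1ccc(N)nc1=O` gives 3 uM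

Among the measured compounds shown here, compound 3 stands as the only number in this assay; the two other values are limits. For the measured compounds named here, the one step between measured compounds, a step that the two limits leave unreadable from compound 1 to compound 2, runs from one limit to another and its size cannot be read.

Compound 4 `Cc1c2cc[n+](C)cc2c(C)c2c3c([nH]c12)C=CC(=O)[C@@]31O[C@@H]2[C@H](O1)[C@@H](COP(=O)(O)O)O[C@H]2n1ccc(N)nc1=O` is not yet measured. It differs from compound 3 by a group of 4 heavy atoms (3 oxygen, 1 phosphorus; no ring) in place of a hydrogen atom, on an oxygen on a saturated carbon. Going by the values given here, no measured step matches this change. The two compounds that already carry the same group of 4 heavy atoms on that oxygen, compound 1 and compound 2, each sit at a limit (the limit of > 0.8 uM in this assay, at which 1 of the 3 values shown sits, (the limit of > 1 uM in this assay, at which 1 of the 3 values shown sits)), so a number for compound 4 is not assured.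

Among the compounds with values here, since no step of the same kind has been read, the step from compound 3 to compound 4 in this assay is estimated at a 2.0-fold higher number from compound 3 to compound 4 (0.30 log units; within the scatter), toward a weaker inhibitor, with wide uncertainty. Compound 4 is expected at 6 uM, with a range from 1.5 uM to 25 uM, and a fair chance that only a limit is reported.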

Compound 4, concentration for 50% inhibition: 12.8 uM
Estimate against measurement, compound 4: 2.1-fold (0.33 log units) below; the measured number falls inside the stated range.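

In this assay, the group of 4 heavy atoms (3 oxygen, 1 phosphorus) in place of a hydrogen atom, on an oxygen on a saturated carbon, now has a readable effect: a 4.3-fold higher number from compound 3 to compound 4 (0.63 log units; beyond the scatter), toward a weaker inhibitor. With compound 4, this group gives a number for the first time among the compounds shown, and this is the only step at this position that can be sized. Of the two other compounds carrying the group, compound 1 gives only a limit: the limit of > 0.8 uM in this assay, at which 1 of the 4 values shown sits. Compound 2 likewise gives only a limit: the limit of > 1 uM in this assay, at which 1 of the 4 values shown sits.

On these data alone, the steps from compound 1 and from compound 2 to compound 4 cannot be read, which leaves the effect of the group on the saturated ring carbon unsized, and whether the step seen here carries over to the groups in compound 1 and compound 2 remains open. As far as these compounds go, it is also open how this assay responds to an amine, a carboxylic acid or a longer chain on the same oxygen, since a single pair defines this position.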